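The compounds below may be only part of what the source reports. "The series", "measured", "known", "first", "only" and "open" are said of these compounds alone.

Measured compounds:
compound 1, `COc1ccc(F)cc1CNCCCNc1ccnc2cc(C3CCCCC3)ccc12`, 2290 nM;
compound 2, `COc1ccc(F)cc1CNCCCNc1ccnc2cc(Cc3ccccc3)ccc12`, 7990 nM.

In an ADME assay on HepG2 cells (Homo sapiens) for cytotoxicity, read by luminescence, CellTiter-Glo and ATP content, with a stated time of 72 h (a higher number here means that more compound is needed for the effect, a lower number that less compound is needed), compound 2 stands at the highest of the two numbers recorded, with compound 1 as its nearest neighbour, and the step of a 3.5-fold higher number from compound 1 to compound 2 (0.54 log units; beyond the scatter) lies beyond the scatter.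

The unmeasured compound 3, `COc1ccc(F)cc1CNCCCNc1ccnc2cc(-c3ccc(C(F)(F)F)cc3)ccc12`, differs from compound 2 in one place: 4-(trifluoromethyl)phenyl in place of benzyl on an aromatic carbon. Among the compounds with values here, the only measured step that touches this position is a 3.5-fold higher number from compound 1 to compound 2 (0.54 log units; beyond the scatter), a modest one. Within the data shown here, no measured pair shows an aryl group placed directly on this carbon, so the direction of the new step rests on that single comparison. Since compound 1 gives 2290 nM and compound 2 gives 7990 nM, a number for compound 3 somewhere between the two is expected, a step of a 2.0-fold lower number from compound 2 to compound 3 (0.30 log units; within the scatter) in this assay. Compound 3 is therefore estimated at 4000 nM, with a range from 1500 nM to 12000 nM.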

Compound 3, half-maximal effective concentration: 5190 nM
Estimate against measurement, compound 3: 1.3-fold (0.11 log units) below; the measured number falls inside the stated range.
By their numbers in this assay, from the lowest: compound 1; then compounds 3 and 2 (each within the scatter of the next).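

In this assay an aromatic ring set directly on this aromatic carbon can now be compared with one held through a single carbon: a 1.5-fold lower number from compound 2 to compound 3 (0.19 log units; within the scatter) lies within the scatter, so 4-(trifluoromethyl)phenyl and benzyl are not told apart here. Against cyclohexyl the change does register, with a 2.3-fold higher number from compound 1 to compound 3 (0.36 log units; beyond the scatter) lying beyond the scatter, so both groups carrying an aromatic ring give a higher number than cyclohexyl among these three compounds. Nothing available explains these numbers.

Going by these compounds, whether an unsubstituted phenyl, an amine or a carboxylic acid at this position would follow the same line remains open. The compounds shown also vary nothing elsewhere on the shared core, so it is unknown whether these steps would hold with a longer chain in the amine side arm.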